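Working notes: expecting compound 4 from compound 2

This account rests on a few compounds, and the source may have more. Where it says the series, first, only, none or still open, it means among the compounds named here.

Measured so far in a functional assay on HL-60 cells (Homo sapiens) for inhibition, read by resazurin assay, with a stated time of 72 h; a higher number here means a weaker inhibitor, a lower number a stronger inhibitor:
compound 1 `CCOc1ccc(C2C(Oc3ccccc3)C(=O)N2c2cc(OC)c(OC)c(OC)c2)cc1` — 494 nM
compound 2 `CCOc1ccc(C2C(O)C(=O)N2c2cc(OC)c(OC)c(OC)c2)cc1` — 11 nM
compound 3 `CCOc1ccc(C2CC(=O)N2c2cc(OC)c(OC)c(OC)c2)cc1` — 88 nM

Compound 2 gives the lowest number of the three in this assay: the step of a 45-fold lower number from compound 1 to compound 2 (1.65 log units; beyond the scatter) is large and the step of an 8.0-fold higher number from compound 2 to compound 3 (0.90 log units; beyond the scatter) is modest, both beyond the scatter, so compound 2 is the strongest inhibitor among the measured compounds. The step of a 5.6-fold lower number from compound 1 to compound 3 (0.75 log units; beyond the scatter) is also modest and beyond the scatter.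

Compound 4 `COc1ccc(C2C(O)C(=O)N2c2cc(OC)c(OC)c(OC)c2)cc1O` differs from compound 2 by 3-hydroxy-4-methoxyphenyl in place of 4-ethoxyphenyl on a saturated ring carbon. All three measured steps alter the oxygen-bearing group on a saturated ring carbon of the shared core and leave the aryl group untouched, so none of them bears on this change. The data give no guide to the aryl change, and the expectation is therefore no step beyond the scatter, with wide uncertainty in either direction.

Compound 4 is expected to give 18 nM in this assay, within 5 nM to 70 nM. This estimate means the step of a 1.6-fold higher number from compound 2 to compound 4 (0.21 log units; within the scatter) is expected.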

Compound 4, half-maximal inhibitory concentration: 5 nM
Compound 4: the middle estimate sits 3.6-fold (0.56 log units) above what was measured; the measured number falls inside the stated range.
By their numbers in this assay, from the lowest: compound 4; then compound 2; then compound 3; then compound 1.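

Unlike the earlier steps, which all alter the oxygen-bearing group on the shared core, this one shows that the aryl group on the saturated ring carbon next to the ring nitrogen also moves the number in this assay (a 2.2-fold lower number from compound 2 to compound 4 (0.34 log units; beyond the scatter)). Within the data shown here, the 4-ethoxyphenyl group is thus not needed for a low number here: 3-hydroxy-4-methoxyphenyl has the same count of heavy atoms, adds a hydrogen-bond donor, and gives the lowest number so far. No measurement shown accounts for this step.

The compounds shown do not separate the added hydroxy group from the shortening of ethoxy to methoxy, and a plain 4-methoxyphenyl group would address that. Also open, as far as these compounds go, is how an amine in place of the 3-hydroxy group would read in this assay.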